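The source may report more compounds than this note shows. Statements on the series, on what has been measured and on what is new or still open speak of the compounds shown alone.

Measured in a functional assay on SK-OV-3 cells (Homo sapiens) for antiproliferative activity, read by MTT assay, with a stated time of 72 h; a higher number here means a weaker inhibitor, a lower number a stronger inhibitor:
- compound 1 `CC(C)c1cccc(NC(=O)CCc2cccc3c2B(O)OC3)c1`: 510 nM
- compound 2 `COc1ccc(NC(=O)CCc2cccc3c2B(O)OC3)cc1OC`: > 100000 nM (a limit of the assay)
- compound 3 `O=C(CCc1cccc2c1B(O)OC2)Nc1ccc(-c2ccccc2)cc1`: 48000 nM

For the measured compounds named here, compound 1 gives the lowest number of the series so far. Compound 3 gives 48000 nM, and its gap to compound 1 lies beyond the scatter.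

Compound 4 `COc1cc(OC)cc(-c2cccc(NC(=O)CCc3cccc4c3B(O)OC4)c2)c1` is not yet measured. It has 3,5-dimethoxyphenyl in place of isopropyl on an aromatic carbon, meta to a large group: 3,5-dimethoxyphenyl in place of isopropyl on an aromatic carbon.

A large upward step in this assay is expected, towards weaker inhibition, since compound 3 gives 48000 nM. That step is estimated as a 9.8-fold higher number from compound 1 to compound 4 (0.99 log units; beyond the scatter). The two structures alone leave this uncertain, so the range is wide. For compound 4 the expected value is 5000 nM, with an estimated range of 400 nM to 60000 nM.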

Compound 4, half-maximal inhibitory concentration: 44 nM
For compound 4 the middle estimate is 110-fold (2.06 log units) above the measured one, outside the stated range (below it).
By their numbers in this assay, from the lowest: compound 4; then compound 1; then compound 3. At a limit, above all of these: compound 2.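

In this assay, for the compounds shown here, the place on an aromatic carbon meta to a large group accepts 3,5-dimethoxyphenyl in place of isopropyl, giving a 12-fold lower number from compound 1 to compound 4 (1.06 log units; beyond the scatter) and the lowest number so far. Going by these compounds alone, the earlier compounds offered no single-change pair, so this is the first direct reading of this place: a larger group carrying a six-membered aromatic ring goes with a lower number, not a higher one. Nothing measured here accounts for the step.

Going by these compounds, it remains open whether the added ring or its two methoxy groups carry the step. Unsubstituted phenyl, pyridine or morpholine at this place would separate those parts.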